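A few compounds are considered here, and "the series" means these few. Any claim that something is new, unique, unknown or untested is made for them only; others in the source may bear on it.

Compound 1 `O=C(Nc1nc2ccccc2s1)c1ccc(OC(F)F)c(OCC2CC2)c1`: 800 ng.h/mL
Compound 2 `O=C(Nc1ccc2ncsc2c1)c1ccc(OC(F)F)c(OCC2CC2)c1`: 1620 ng.h/mL

In an ADME assay on the whole organism (strain Sprague-Dawley) for pharmacokinetics, with Rattus norvegicus as the target, read by HPLC, at a dose of 1 mg/kg by the subcutaneous route (on this read-out lower numbers stand for lower exposure and higher numbers for higher exposure at the dose given), compound 2 stands highest of the two measured compounds at 1620 ng.h/mL, while compound 1 gives 800 ng.h/mL. Among the measured compounds shown here, the only measured step is a 2.0-fold higher number from compound 1 to compound 2 (0.31 log units; beyond the scatter), a modest move that puts 1,3-benzothiazol-6-yl in place of 1,3-benzothiazol-2-yl on an amide-type nitrogen.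

Compound 3 `O=C(Nc1ccc2nc(S)sc2c1)c1ccc(OC(F)F)c(OCC2CC2)c1` differs from compound 2 at a single place: sulfanyl in place of hydrogen on an aromatic carbon. This is sulfanyl in place of hydrogen on an aromatic carbon. For the measured compounds named here, no measured step adds this group, so the data give no direct guide to its effect. Going by the values given here, the step to compound 2, a 2.0-fold higher number from compound 1 to compound 2 (0.31 log units; beyond the scatter), shows only that one structural change can move this read-out by a modest amount, so it serves as a rough yardstick for size and says nothing about direction. With compound 2 the higher of just two values, a small fall seems a little likelier than a further rise, and it may not clear the scatter. The expected step is a 1.5-fold lower number from compound 2 to compound 3 (0.17 log units; within the scatter). For compound 3 the estimated value is 1100 ng.h/mL, with an expected range from 400 ng.h/mL to 2800 ng.h/mL.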

Compound 3, area under the concentration-time curve: 1040 ng.h/mL
The estimate for compound 3 lay 1.1-fold (0.02 log units) above the measured number; measured number inside the range.
By their numbers in this assay, from the lowest: compounds 1, 3 and 2 (each within the scatter of the next, the first and the last beyond it).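

In this assay, among the compounds shown here, sulfanyl in place of hydrogen on an aromatic carbon, next to the ring nitrogen and next to the ring sulfur, gives a 1.6-fold lower number from compound 2 to compound 3 (0.19 log units; within the scatter) and so stays within the normal spread of repeat measurements, which means this position, untouched by the earlier compounds, takes the new group without a clear shift in exposure. For the compounds shown here, of the two single changes seen so far, only the one on the amide-type nitrogen, a 2.0-fold higher number from compound 1 to compound 2 (0.31 log units; beyond the scatter), clears that spread, while the sulfanyl change does not. Nothing in the data at hand gives a reason for this result.

From the compounds shown here alone, it remains open whether this tolerance belongs to the position or to sulfanyl alone, since a single group cannot separate the two, and a methyl, an amine or a methylsulfanyl group at the same carbon would help to tell them apart. Going by these compounds, it is also open whether the same change would behave alike on the core of compound 1, where the amide-type nitrogen carries 1,3-benzothiazol-2-yl instead.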